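A few compounds are considered here, and "the series" means these few. Any claim that something is new, unique, unknown or untested is made for them only; others in the source may bear on it.

In a functional assay on MCF7 cells (Homo sapiens) for inhibition, read by CCK-8 assay, with a stated time of 48 h (a higher number here means a weaker inhibitor of growth, a lower number a stronger inhibitor of growth), compound 3 `CN1CCN(c2ccc(Nc3ncc(Cl)c(NCc4ccc(C(F)(F)F)cc4)n3)nc2)CC1` stands at the top of the two numbers that have been reported, giving 28400 nM. The nearest reported number belongs to compound 2 `Cc1ccccc1Nc1nc(Nc2ccc(N3CCNCC3)cn2)ncc1Cl`, which gives 3410 nM, a gap that lies beyond the scatter of the assay. Compound 1 `Cc1ccccc1Nc1nc(Nc2cc(Cl)ccn2)ncc1Cl` is reported only as a limit in this assay, > 100000 nM, and sits at the limit of > 100000 nM in this assay, at which 1 of the 3 values shown sits, rather than at a measured number.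

Compound 4 `COc1cccc(Nc2nc(Nc3ccc(N4CCN(C)CC4)cn3)ncc2Cl)c1` has not yet been measured in this assay. It differs from compound 3 in one place: 3-methoxyphenyl in place of 4-(trifluoromethyl)benzyl on a nitrogen on an aromatic ring. The two compounds share the remainder of their structure, including the methylpiperazine on the same side of the shared core.

Compound 2 and compound 4 both carry a substituted phenyl on that nitrogen, whereas compound 3 carries a benzyl there. On that basis the author expects compound 4 to give a lower number than compound 3, a step of a 7.1-fold lower number from compound 3 to compound 4 (0.85 log units; beyond the scatter) in this assay, landing nearer to the number given by compound 2. The expected value for compound 4 in this assay is 4000 nM, with a range from 1000 nM to 16000 nM.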

Compound 4, concentration for 50% growth inhibition: 7540 nM
Compound 4: middle estimate off by 1.9-fold (0.28 log units), on the low side, and the stated range covers the measured number.
By their numbers in this assay, from the lowest: compound 2; then compound 4; then compound 3. At a limit, above all of these: compound 1.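

In this assay, the group carried on the nitrogen on an aromatic ring turns out to matter when the rest of the structure, including the methylpiperazine, is held the same: 3-methoxyphenyl in place of 4-(trifluoromethyl)benzyl brings a modest change, a 3.8-fold lower number from compound 3 to compound 4 (0.58 log units; beyond the scatter). This is the first pair among the compounds shown that differ in one place, and the earlier compounds gave no reading of this position on its own. The change alters the link to the ring and the substituent on it in a single step, and no measurement shown bears on why the number moved.

As far as these compounds go, whether the step follows the removal of the benzyl link or the exchange of trifluoromethyl for methoxy stays open, and a 4-(trifluoromethyl)phenyl or a 3-methoxybenzyl on the same nitrogen would separate the two. Also open, from the compounds shown here alone, is how this position responds to a group of another kind, such as an amine, a carboxylic acid or a longer chain ending in a hydroxyl, in place of the methoxy.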